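From amino to dimethylamino on the carbonyl carbon

A few compounds are considered here, and "the series" means these few. Any claim that something is new, unique, unknown or untested is made for them only; others in the source may bear on it.

Measured so far in an ADME assay on L929 cells (Mus musculus) for cytotoxicity, read by resazurin assay, with a stated time of 48 h; on this read-out lower numbers stand for higher toxicity in this test and higher numbers for lower toxicity in this test:
- compound 1 `N#CCn1c2ccc([N+](=O)[O-])cc2c(=O)n1Cc1ccccc1`: > 256000 nM (a limit, not a number)
- compound 2 `NC(=O)CCCn1c2ccc([N+](=O)[O-])cc2c(=O)n1Cc1ccccc1`: > 256000 nM (a limit, not a number)

Compound 2 has no numerical value in this assay, only the limit given above. Among the compounds with values here, the one measured step is a step that the two limits leave unreadable from compound 1 to compound 2. All that the series shows so far is the limit of > 256000 nM in this assay, at which 2 of the 2 values shown sit.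

Compound 3 `CN(C)C(=O)CCCn1c2ccc([N+](=O)[O-])cc2c(=O)n1Cc1ccccc1` carries dimethylamino in place of amino on a carbonyl carbon. Within the data shown here, the one measured step bears on this change only loosely, as it lies elsewhere in the side chain and offers no size to carry over. No step beyond the scatter is therefore expected in this assay, and no direction is favoured. This expectation rests on the limit of compound 2, > 256000 nM.

The expected size is a step that the limit leaves unreadable from compound 2 to compound 3. Compound 3 is estimated at 300000 nM, with an expected range of 150000 nM to 600000 nM, and a report as a limit is the likeliest outcome.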

Compound 3, concentration lethal to 50% of the cells: > 256000 nM
Compound 3: no number, only a limit; the forecaster's own chance of this, stated with the estimate: 85%; the middle value lies beyond the limit too.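

In this assay compound 3 gives > 256000 nM as a limit and not a number. No step can be read among compound 1, compound 2 and compound 3. The compounds shown leave open whether any change in the side chain shifts this read-out, because all of them rest on one shared value: the limit of > 256000 nM in this assay, at which 3 of the 3 values shown sit.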